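Extending the side chain of compound 3

This account rests on a few compounds, and the source may have more. Where it says the series, first, only, none or still open, it means among the compounds named here.

In a functional assay on NCI-H460 cells (Homo sapiens) for inhibition, read by sulforhodamine B assay, with a stated time of 72 h (on this read-out higher numbers stand for weaker inhibition and lower numbers for stronger inhibition), compound 1 `CC(C)c1cc(-n2cc(-c3ccc(CN4CCN(Cc5ccccc5)CC4)cc3)nn2)c(O)cc1O` gives > 1000 nM, which is a limit of the assay and not a number. Compound 2 `CC(C)c1cc(-n2nncc2-c2ccc(CN3CCCC(O)C3)cc2)c(O)cc1O` gives 45 nM. Compound 3 `CCNC(=O)c1nnn(-c2cc(C(C)C)c(O)cc2O)c1-c1ccc(CN(CC)CC)cc1` gives 11 nM, the lower of the two actual numbers, and its gap to compound 2 lies beyond the scatter.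

Compound 4 `CCNC(=O)c1nnn(-c2cc(C(C)C)c(O)cc2O)c1-c1ccc(CNCCCN(CC)CC)cc1` is still to be measured. It differs from compound 3 as follows: (3-(diethylamino)propyl)amino in place of diethylamino on a saturated chain carbon bound to an aromatic carbon. In words, (3-(diethylamino)propyl)amino stands in place of diethylamino on a saturated chain carbon bound to an aromatic carbon.

Going by the values given here, no measured pair shows this change, so the expectation in this assay is loose. It starts from compound 3 at 11 nM. The upper end stays wide since compound 1 gives > 1000 nM, again a limit. A modest step of a 2.3-fold higher number from compound 3 to compound 4 (0.36 log units; beyond the scatter) is expected, towards weaker inhibition, and it may not clear the scatter by much. For compound 4 the estimated value is 25 nM, with an expected range of 8 nM to 90 nM.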

Compound 4, half-maximal inhibitory concentration: 412 nM
For compound 4 the middle estimate is 16-fold (1.22 log units) below the measured one; measured number above the stated range.
By their numbers in this assay, from the lowest: compound 3; then compound 2; then compound 4. At a limit, above all of these: compound 1.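

In this assay the saturated chain carbon bound to an aromatic carbon proves sensitive to what it carries: a 37-fold higher number from compound 3 to compound 4 (1.57 log units; beyond the scatter) comes with (3-(diethylamino)propyl)amino in place of diethylamino, with the rest of the molecule unchanged. Going by these compounds alone, the earlier compounds differ from one another in more than one place, so this is the only step that isolates this position. Compound 4 still gives a number rather than a limit, so this step can be read in full, which no comparison with compound 1 allows: the limit of > 1000 nM in this assay, at which 1 of the 4 values shown sits.

The step does not separate the longer chain from the added amine hydrogen or the second nitrogen, and it gives no cause for the loss. A shorter (2-(diethylamino)ethyl)amino chain or a piperidine at this place would help to separate these changes.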